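This account rests on a few compounds, and the source may have more. Where it says the series, first, only, none or still open, it means among the compounds named here.

In an assay on BaF3 cells for inhibition of proto-oncogene tyrosine-protein kinase receptor Ret variant V804M (Homo sapiens), read by MTT assay, with a stated time of 48 h (on this read-out higher numbers stand for weaker inhibition of growth and lower numbers for stronger inhibition of growth), the measured compounds stand as follows.
Compound 1, `CCc1cc(-c2nn(C(C)C)c3ncnc(N)c23)no1`, gives 5770 nM.
Compound 2, `CC(C)n1nc(-c2cc(C3CCCCC3)on2)c2c(N)ncnc21`, gives 4730 nM.
Compound 3, `CC(C)n1nc(-c2cc(-c3ccc(F)cc3)on2)c2c(N)ncnc21`, gives only a limit of the assay, > 10000 nM.

Compound 3 sits at the limit of > 10000 nM in this assay, at which 1 of the 3 values shown sits. Against compound 2 it is the weaker one, an at least 2.1-fold higher number from compound 2 to compound 3 (0.32 log units; beyond the scatter), whereas the gap from compound 1, an at least 1.7-fold higher number from compound 1 to compound 3 (0.23 log units; that floor lies within the scatter), lies within the scatter. Compound 4, `CC(C)c1cc(-c2nn(C(C)C)c3ncnc(N)c23)no1`, differs from compound 3 by isopropyl in place of 4-fluorophenyl on an aromatic carbon. The step that bears on this is the one between the two alkyl groups, a 1.2-fold lower number from compound 1 to compound 2 (0.09 log units; within the scatter), which lies within the scatter, so ethyl and cyclohexyl give much the same number while 4-fluorophenyl gives only a limit. Isopropyl, with no ring, is expected to resemble those alkyls, so in this assay a fall in the number is expected, an at least 1.8-fold lower number from compound 3 to compound 4 (0.27 log units; that floor lies within the scatter). Compound 4 is therefore estimated at 5300 nM, with a range from 2500 nM to 11000 nM.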

Compound 4, concentration for 50% growth inhibition: 5900 nM
For compound 4 the middle estimate is 1.1-fold (0.05 log units) below the measured one; the measured number falls inside the stated range.
By their numbers in this assay, from the lowest: compounds 2, 1 and 4 (each within the scatter of the next). At a limit, above all of these: compound 3.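

In this assay, isopropyl on this carbon next to the ring oxygen shows no separation from ethyl, a 1.0-fold higher number from compound 1 to compound 4 (0.01 log units; within the scatter), or from cyclohexyl, a 1.2-fold higher number from compound 2 to compound 4 (0.10 log units; within the scatter), so three alkyl groups of different size cannot be told apart here. Replacing 4-fluorophenyl with isopropyl gives an at least 1.6-fold lower number from compound 3 to compound 4 (0.22 log units; that floor lies within the scatter). Compound 3 carries only a limit of the assay, so that step is a floor and its true size is unknown: the limit of > 10000 nM in this assay, at which 1 of the 4 values shown sits.

The compounds shown leave open whether an amine, a carboxylic acid or a plain phenyl on this carbon would move the number away from that of the alkyl groups.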